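The source may hold more compounds than are shown below. What is called first, only, known or untested is meant among the compounds shown, and "the series" means these compounds.

Compound 2 `COc1ccc(NC(=O)[C@@H](NC(=O)c2cc(Cl)ccc2O)C(C)C)cc1` was tested in a functional assay on K562 cells (Homo sapiens) for cytotoxicity, with a stated time of 72 h; a higher number here means a weaker inhibitor, a lower number a stronger inhibitor. In this assay compound 2 gives > 10000 nM, which is a limit of the assay and not a number. Compound 1 `CC(C)[C@H](NC(=O)c1cc(Cl)ccc1O)C(=O)Nc1ccc(Cl)cc1` differs from compound 2 only in carrying chloro where compound 2 carries methoxy. In this assay compound 1 gives > 20000 nM, likewise a limit of the assay. Going by the values given here, the one measured step, a step that the two limits leave unreadable from compound 1 to compound 2, cannot be read in size because the limit of > 10000 nM in this assay, at which 1 of the 2 values shown sits, and the limit of > 20000 nM in this assay, at which 1 of the 2 values shown sits, are both limits. Compound 3 `CC(C)[C@H](NC(=O)c1cc(Cl)ccc1O)C(=O)Nc1ccc(C(F)(F)F)cc1` has not yet been measured; it differs from compound 2 by trifluoromethyl in place of methoxy on an aromatic carbon. Among the compounds with values here, no measured step bears readably on this change, so the numbers give no direction for it. Compound 3 is therefore expected to stay near the limit, with the step that the limit leaves unreadable from compound 2 to compound 3 estimated as small. The estimate for compound 3 in this assay is 15000 nM, expected to fall between 3000 nM and 100000 nM.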

Compound 3, half-maximal inhibitory concentration: 4500 nM
Beside the measured number, compound 3's estimate is 3.3-fold (0.52 log units) above it; measured number inside the range.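

At this position, para to a large group, trifluoromethyl gives the first result in this assay that is a number and not a limit of the assay. Trifluoromethyl in place of methoxy brings an at least 2.2-fold lower number from compound 2 to compound 3 (0.34 log units; beyond the scatter), and trifluoromethyl in place of chloro brings an at least 4.4-fold lower number from compound 1 to compound 3 (0.64 log units; beyond the scatter). Each of these sizes is only a floor, and the true gaps may be larger, since compound 1 and compound 2 are known only as limits of the assay.

The step from compound 1 to compound 2 still cannot be read, so chloro and methoxy cannot be ranked against each other. From the compounds shown here alone, how a nitrile, an amine or a carboxylic acid at this same position would compare with trifluoromethyl remains open.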